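Swapping an aminophenyl for an aminopyridinyl on a nitroimidazole scaffold

The source may hold more compounds than are shown below. What is called first, only, known or untested is meant among the compounds shown, and "the series" means these compounds.

Compound 1 `Cc1ncc([N+](=O)[O-])n1CCSc1nnc(-c2ccccc2N)o1` was tested in a functional assay on SGC-7901 cells (Homo sapiens) for cytotoxicity, read by MTT assay, with a stated time of 48 h (on this read-out lower numbers stand for stronger inhibition and higher numbers for weaker inhibition), where compound 1 gives 35100 nM. This is the higher of the two numbers measured; compound 2 `COc1cc(OC)cc(-c2nnc(SCCn3c([N+](=O)[O-])cnc3C)o2)c1` gives 9600 nM in this assay, a gap described as beyond the usual scatter. Compound 3 `Cc1ncc([N+](=O)[O-])n1CCSc1nnc(-c2ccc(N)nc2)o1` is not yet measured. It differs from compound 1 in one place: 6-aminopyridin-3-yl in place of 2-aminophenyl on an aromatic carbon. Going by the values given here, with no measured step of this kind to lean on, the change from compound 1 to compound 3 is expected to be small, a 1.2-fold lower number from compound 1 to compound 3 (0.07 log units; within the scatter), with no direction beyond the scatter. Compound 3 is estimated at 30000 nM, between 12000 nM and 75000 nM.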

Compound 3, half-maximal inhibitory concentration: 30900 nM
For compound 3 the middle estimate is 1.0-fold (0.01 log units) below the measured one; low and high end bracket the measured number.
By their numbers in this assay, from the lowest: compound 2; then compounds 3 and 1 (each within the scatter of the next).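

In this assay, the swap gives a 1.1-fold lower number from compound 1 to compound 3 (0.06 log units; within the scatter), so at this aromatic carbon the data do not separate 6-aminopyridin-3-yl from 2-aminophenyl. The entering group brings a ring nitrogen and one more hydrogen-bond acceptor, yet the number shows no change beyond the scatter. No measured evidence here bears on why.

On these data alone, both groups carry an amine on a six-membered aromatic ring, so the need for that amine remains untested. As far as these compounds go, whether a carboxylic acid or a morpholine at this carbon would shift the number beyond the scatter also stays open.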